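The compounds below may be only part of what the source reports. "The series", "measured", "known", "first", "only" and "open" are said of these compounds alone.

Measured so far:
compound 1 `NS(=O)(=O)Oc1ccc2c(c1)CN(C(=O)c1ccc(N3CCCCC3)cc1)CC2`, 38.3%
compound 2 `CCN(Cc1ccccn1)c1cccc(C(=O)N2CCc3ccc(OS(N)(=O)=O)cc3C2)c1`, 19.9%
compound 3 `CN(C)CCN(CCN(C)C)c1ccc(C(=O)N2CCc3ccc(OS(N)(=O)=O)cc3C2)cc1`, 15.9%

All three share one core and differ only in the amine on the benzamide ring. In an assay on HEK293 cells for inhibition of Steryl-sulfatase (Homo sapiens), tested at 1 uM (a higher number here means a stronger effect of the compound at the concentration tested, a lower number a weaker effect), compound 1 gives 38.3%, compound 2 gives 19.9% and compound 3 gives 15.9%. Compound 2 thus stands second of the three: its value and that of compound 3 lie within the scatter of each other, while compound 1 sits higher by a margin beyond the scatter. Among the compounds with values here, the only single-point step among the measured compounds is a number 22.4 percentage points lower from compound 1 to compound 3 (beyond the scatter), and that exchange sits on a different ring position from the change now considered, so it bears on it only loosely.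

Compound 4 `CCCN(Cc1ccccc1)c1cccc(C(=O)N2CCc3ccc(OS(N)(=O)=O)cc3C2)c1` is the next case. It differs from compound 2 by benzyl(propyl)amino in place of ethyl((pyridin-2-yl)methyl)amino on an aromatic carbon. Within the data shown here, no measured pair isolates this kind of exchange. Among the measured compounds shown here, the one step known, from compound 1 to compound 3, shows that a change of the amine can move this assay by a modest amount; the present change is smaller in kind, and no direction can be read from the data. The expectation is therefore no step beyond the scatter, a number 2.1 percentage points higher from compound 2 to compound 4 (within the scatter). Compound 4 is expected at 22%, with a range from 8% to 38%.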

Compound 4, a percentage reported as inhibition, at one concentration (the size of the read-out at that concentration, not a potency): 67.4%
Compound 4: middle estimate off by 45.4 percentage points, on the low side, outside the stated range (above it).
By their numbers in this assay, from the lowest: compounds 3 and 2 (each within the scatter of the next); then compound 1; then compound 4.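

In this assay, benzyl(propyl)amino in place of ethyl((pyridin-2-yl)methyl)amino gives a number 47.5 percentage points higher from compound 2 to compound 4 (beyond the scatter), so the choice of amine on this aromatic carbon, meta to a large group, can move the read-out by a large amount even between two groups of similar heavy-atom count. Within the data shown here, the exchange alters two things at once, a six-membered aromatic ring with 1 hetero atom becoming one of carbon only and ethyl becoming propyl, and the single pair cannot assign the step to either; it is also printed as large, whereas a number 22.4 percentage points lower from compound 1 to compound 3 (beyond the scatter) is printed as modest. No measurement at hand explains the size of this step.

The compounds shown leave open which part of the exchange carries the step, and a benzyl(ethyl)amino or a propyl((pyridin-2-yl)methyl)amino group would separate the two. Also open, going by these compounds, is how the read-out responds to a fluorine or a methoxy group on the benzyl ring, and whether benzyl(propyl)amino holds its effect when placed where compound 1 carries its piperidin-1-yl.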